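The compounds below may be only part of what the source reports. "The series", "measured", "known", "first", "only" and "open" are said of these compounds alone.

Compound 1 `COc1cccc(OC)c1N1C(=O)CSC1c1cccc(C(=O)NCCCCc2ccccc2)c1` gives 95% in a functional assay on HOS-TE85 cells (Homo sapiens) for inhibition, read by CCK-8 assay, with a stated time of 72 h, tested at 1 uM (a lower number here means less inhibition, a higher number more inhibition at the concentration tested (going by the name of the read-out)), whereas compound 2 `CCN1C(=O)CSC1c1cccc(C(=O)NCCCCc2ccccc2)c1` gives 0%. Within the data shown here, compound 2 thus stands lowest of the two numbers measured so far, its only neighbour being compound 1, which lies far above it, the single step being a number 95 percentage points lower from compound 1 to compound 2 (beyond the scatter). Compound 3 `COc1cc(F)ccc1N1C(=O)CSC1c1cccc(C(=O)NCCCCc2ccccc2)c1` is not yet measured; it differs from compound 2 as follows: 4-fluoro-2-methoxyphenyl in place of ethyl on an amide-type nitrogen in a ring. Among the measured compounds shown here, the change reverses the direction of the one measured step, so a large rise is expected, a number 80 percentage points higher from compound 2 to compound 3 (beyond the scatter). Compound 3 is estimated at 80%, within 40% to 100%.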

Compound 3, a percentage reported as inhibition, at one concentration (the size of the read-out at that concentration, not a potency): 94%
Compound 3: middle estimate off by 14 percentage points, on the low side, within the range that was stated.
By their numbers in this assay, from the lowest: compound 2; then compounds 3 and 1 (each within the scatter of the next).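

With 4-fluoro-2-methoxyphenyl in place of ethyl on the amide-type nitrogen in a ring, the step is a number 94 percentage points higher from compound 2 to compound 3 (beyond the scatter), so the high number at this position does not belong to 2,6-dimethoxyphenyl alone. Exchanging one aryl group for the other gives a number 1 percentage points lower from compound 1 to compound 3 (within the scatter), so these two substituted phenyl groups cannot be told apart here. No supporting data explain either step.

The compounds shown leave open how plain phenyl or a pyridine ring would fare at this position. Also open, on these data alone, is whether a benzyl group would track the aryl groups or ethyl.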